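A few compounds are considered here, and "the series" means these few. Any claim that something is new, unique, unknown or untested is made for them only; others in the source may bear on it.

The study at hand compares three compounds in an ADME assay on HEK293 cells (Homo sapiens) for cytotoxicity, with a stated time of 72 h; on this read-out lower numbers stand for an effect already at smaller amounts and higher numbers for an effect only at larger amounts of compound. Compound 1, `Cc1cc(NC(=O)Nc2ccc(C(=O)O)cc2)c2ccccc2n1`, is reported there only as a limit of > 25000 nM. Compound 2, `COc1ccc(NC(=O)Nc2cc(C)nc3ccccc23)cc1F`, likewise reaches only the limit of > 25000 nM in this assay. Compound 3, `Cc1cc(NC(=O)Nc2cccc(C(N)=O)c2)c2ccccc2n1`, also gives no number but the limit of > 25000 nM. Compound 1 thus stands at the limit of > 25000 nM in this assay, at which 3 of the 3 values shown sit, and none of the three results offers a number by which the compounds could be ordered. Compound 4, `CSc1ccc(NC(=O)Nc2cc(C)nc3ccccc23)cc1`, has not yet been measured in this assay; it differs from compound 1 by methylsulfanyl in place of carboxy on an aromatic carbon. For the measured compounds named here, with no pair of measured compounds differing in a single place, no size of step is known from these data. Given that compound 1 sits at the limit of > 25000 nM in this assay, at which 3 of the 3 values shown sit, compound 4 is expected to behave the same way, and the step of a number no higher from compound 1 to compound 4 (the limit leaves the size open) is expected to be none beyond the scatter. The estimate for compound 4 in this assay is therefore 25000 nM, with a range from 10000 nM to 60000 nM, and most probably it will again be reported only as a limit.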

Compound 4, half-maximal effective concentration: 24000 nM
The estimate for compound 4 lay 1.0-fold (0.02 log units) above the measured number, within the range that was stated.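

In this assay, compound 4 is the only compound shown that gives a number rather than a limit, at 24000 nM. Compound 1 is reported only as a limit, > 25000 nM. For methylsulfanyl in place of carboxy on an aromatic carbon, para to a large group, the step is an at least 1.0-fold lower number from compound 1 to compound 4 (0.01 log units; that floor lies within the scatter), so this change at this position is not shown to move the read-out beyond the scatter, although the limit leaves the true size of the step open.

Most of the picture still rests on a single limit: the limit of > 25000 nM in this assay, at which 3 of the 4 values shown sit. Whether an amine, a hydroxyl group or a longer chain such as ethylsulfanyl at this position would give a number, and how that number would compare with compound 4, remains open.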